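Replacing the 4-methoxyphenyl group of compound 3 with 3-chlorophenyl

A few compounds are considered here, and "the series" means these few. Any claim that something is new, unique, unknown or untested is made for them only; others in the source may bear on it.

In a functional assay on MCF7 cells (Homo sapiens) for cytotoxicity, read by MTT assay, with a stated time of 72 h (on this read-out lower numbers stand for stronger inhibition and higher numbers for weaker inhibition), compound 1 `O=C1C(=Cc2ccc(Br)cc2)C(=O)N(c2ccc(Cl)cc2)N1c1ccc(Cl)cc1` gives 30400 nM and compound 2 `COc1cc(C=C2C(=O)N(c3ccc(Cl)cc3)N(c3ccc(Cl)cc3)C2=O)ccc1O` gives 22800 nM, values within the scatter of each other, as a 1.3-fold lower number from compound 1 to compound 2 (0.12 log units; within the scatter) shows. Compound 3 `COc1ccc(C=C2C(=O)N(c3ccc(Cl)cc3)N(c3ccc(Cl)cc3)C2=O)cc1` reaches only > 128000 nM, which is a limit of the assay and not a number. Compound 4 `O=C1C(=Cc2cccc(Cl)c2)C(=O)N(c2ccc(Cl)cc2)N1c1ccc(Cl)cc1` carries 3-chlorophenyl in place of 4-methoxyphenyl on a double-bonded chain carbon bound to a double-bonded ring carbon. For the measured compounds named here, two measured steps bear on this change: an at least 4.2-fold higher number from compound 1 to compound 3 (0.62 log units; beyond the scatter) and an at least 5.6-fold higher number from compound 2 to compound 3 (0.74 log units; beyond the scatter), both beyond the scatter. Compound 1, with 4-bromophenyl, is the nearest match, though a loose one. The expected step, toward a lower number and of similar size, is an at least 3.6-fold lower number from compound 3 to compound 4 (0.56 log units; beyond the scatter). The estimate for compound 4 is 35000 nM, with an expected range from 12000 nM to 100000 nM.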

Compound 4, half-maximal inhibitory concentration: 18300 nM
Compound 4: the middle estimate sits 1.9-fold (0.28 log units) above what was measured; measured number inside the range.
By their numbers in this assay, from the lowest: compounds 4, 2 and 1 (each within the scatter of the next). At a limit, above all of these: compound 3.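

In this assay, 3-chlorophenyl in place of 4-methoxyphenyl gives an at least 6.9-fold lower number from compound 3 to compound 4 (0.84 log units; beyond the scatter), so a change at this place alone separates compound 3 from a measurable value. The new group also joins the others without a distinguishable difference, with a 1.2-fold lower number from compound 2 to compound 4 (0.10 log units; within the scatter) and a 1.7-fold lower number from compound 1 to compound 4 (0.22 log units; within the scatter), so 3-chlorophenyl, 4-bromophenyl and 4-hydroxy-3-methoxyphenyl cannot be told apart here. The entry for compound 3 remains a limit of the assay and not a number: the limit of > 128000 nM in this assay, at which 1 of the 4 values shown sits.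

The compounds shown leave open how an unsubstituted phenyl or a 4-aminophenyl group would read at this place. They also leave open whether a carboxylic acid there would fall with these three compounds or with compound 3.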